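A few compounds are considered here, and "the series" means these few. Any claim that something is new, unique, unknown or untested is made for them only; others in the source may bear on it.

Going by the values given here, in a functional assay on Huh-7 cells (Homo sapiens) for cytotoxicity, read by MTT assay, with a stated time of 3 days (a higher number here means that more compound is tolerated, a lower number that less compound is tolerated), compound 1 `CN(Cc1ncnc2c1ncn2[C@@H]1O[C@H](CO)[C@@H](O)[C@H]1O)c1ccccc1` gives 21000 nM as the only exact number so far. Compound 2 `O=c1ccn(Cc2ncnc3c2ncn3[C@@H]2O[C@H](CO)[C@@H](O)[C@H]2O)cc1` gives > 100000 nM as a limit of the assay. Compound 3 `OC[C@H]1O[C@@H](n2cnc3c(COc4ccccn4)ncnc32)[C@H](O)[C@@H]1O` gives > 250000 nM as a limit too. Compound 4 `CSCc1ncnc2c1ncn2[C@@H]1O[C@H](CO)[C@@H](O)[C@H]1O` differs from compound 1 in one group (methylsulfanyl in place of methyl(phenyl)amino on a saturated chain carbon bound to an aromatic carbon): methylsulfanyl stands in place of methyl(phenyl)amino on a saturated chain carbon bound to an aromatic carbon. Two measured swaps of that same group bear on this: one gave an at least 4.7-fold higher number from compound 1 to compound 2 (0.67 log units; beyond the scatter) and the other gave an at least 11-fold higher number from compound 1 to compound 3 (1.07 log units; beyond the scatter) with a ring entering each time. Methylsulfanyl has no ring, so a rise in this assay is expected, but its size is uncertain. The expected step is a 3.3-fold higher number from compound 1 to compound 4 (0.52 log units; beyond the scatter) on this reasoning. Compound 4 is estimated at 70000 nM (expected range 15000 nM to 250000 nM).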

Compound 4, half-maximal cytotoxic concentration: > 100000 nM
Compound 4: only a limit was reported (the forecaster's own chance of this, stated with the estimate: 45%); middle value at least 1.4-fold (0.15 log units) away from the limit.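

With methylsulfanyl in place of methyl(phenyl)amino on this saturated chain carbon, this assay shows an at least 4.7-fold higher number from compound 1 to compound 4 (0.67 log units; beyond the scatter). A ring in the entering group is therefore not needed for this rise, which compound 2 and compound 3 could not show, since each brought a ring of its own. The steps from compound 2 and compound 3 to compound 4 cannot be read, because their values are all limits: the limit of > 100000 nM in this assay, at which 2 of the 4 values shown sit.

Going by these compounds, how much compound 4 is truly tolerated stays open. So does whether a small amine or a carboxylic acid at this place would also raise the number.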